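Swapping a Benzoyl Hydrazide for a Hydrazone

The source may hold more compounds than are shown below. What is called first, only, known or untested is meant among the compounds shown, and "the series" means these compounds.

Measured so far in an assay for inhibition of Amine oxidase [flavin-containing] A (Bos taurus), read by fluorescence, with a stated time of 60 min; a higher number here means a weaker inhibitor, a lower number a stronger inhibitor:
- compound 1, `O=C(NNc1nc2ccccc2nc1Cc1ccccc1)c1ccc(O)cc1`: 1.7 nM
- compound 2, `O=C(Cn1c(=O)c(Cc2ccccc2)nc2ccccc21)NNC(=O)c1ccc(Cl)cc1`: 64 nM

Of the compounds shown here, two have been measured in this assay. Compound 1 gives 1.7 nM, while compound 2 gives 64 nM. Compound 2 therefore stands at the higher of the two numbers, the weaker inhibitor; the gap to compound 1 lies well beyond the usual scatter. The two compounds share no single point of difference, so nothing in these two values tells how much of that gap comes from any one part of the structure.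

Compound 3, `O=C(Cn1c(=O)c(Cc2ccccc2)nc2ccccc21)N/N=C/c1ccc(Br)cc1`, keeps the core of compound 2 and changes one group: a group of 9 heavy atoms (7 carbon, 1 nitrogen, 1 bromine; one six-membered aromatic ring of carbon only) in place of a group of 10 heavy atoms (7 carbon, 1 nitrogen, 1 oxygen, 1 chlorine; one six-membered aromatic ring of carbon only), on an amide-type nitrogen. Going by the values given here, no measured pair shows this change, so there is no direct guide to its size or direction. The expectation for compound 3 is a modest shift, with the step from compound 2 estimated at a 1.6-fold lower number from compound 2 to compound 3 (0.20 log units; within the scatter), small enough that a result within the scatter of compound 2 would not surprise. The value of compound 3 in this assay is thus estimated at 40 nM, within a range from 8 nM to 200 nM.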

Compound 3, half-maximal inhibitory concentration: 22 nM
The estimate for compound 3 lay 1.8-fold (0.26 log units) above the measured number; the range from low to high includes it.
By their numbers in this assay, from the lowest: compound 1; then compound 3; then compound 2.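

The group on the amide-type nitrogen turns out to matter in this assay: replacing the ((4-chlorophenyl)carbonyl)amino group of compound 2 with the bromine-bearing hydrazone group of compound 3 gives a 2.9-fold lower number from compound 2 to compound 3 (0.46 log units; beyond the scatter), a modest step but one that a repeat measurement would not be expected to produce by chance. The step also shows that this position does not need the carbonyl of the leaving group, and that a group with 0 hydrogen-bond donors in place of 1 still gives an inhibitor in the nanomolar range. Several things change together here, including the carbonyl, the link to the ring and the halogen (chlorine to bromine), and nothing available explains the gain or shows which of these changes produced it.

Separating those changes would take a pair that differs in only one of them, such as the same hydrazone with chlorine in place of bromine, or the benzoyl hydrazide with bromine in place of chlorine. Also open, as far as these compounds go, is how the hydrazone behaves with other groups on its ring, such as a methoxy group, an amine or a carboxylic acid, or with no substituent on the ring at all.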